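The compounds below may be only part of what the source reports. "The series", "measured", "known", "first", "only" and "open" are said of these compounds alone.

Compound 1 `Cc1nc(N)c2c(-c3ccccc3)cn([C@@H]3O[C@H](CO)[C@@H](O)[C@H]3O)c2n1` — in a functional assay on HepG2 cells (Homo sapiens) for antiproliferative activity, read by XTT assay, with a stated time of 72 h (a higher number here means a weaker inhibitor, a lower number a stronger inhibitor), compound 1 gives > 20000 nM, a limit of the assay.
Compound 2 `Cc1nc(N)c2c(I)cn([C@@H]3O[C@H](CO)[C@@H](O)[C@H]3O)c2n1` — in this assay compound 2 gives 6310 nM.
Compound 3 `CNc1ncnc2c1c(I)cn2[C@@H]1O[C@H](CO)[C@@H](O)[C@H]1O` — in this assay compound 3 gives > 20000 nM, a limit of the assay.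

Compound 1 and compound 2 share one core, compound 3 carries another; the difference between the two cores is not broken down here. Compound 4 `CNc1ncnc2c1c(-c1ccccc1)cn2[C@@H]1O[C@H](CO)[C@@H](O)[C@H]1O` bears the second core and differs from compound 3 by the same change that leads from compound 2 to compound 1: phenyl in place of iodo on an aromatic carbon in the first pair, phenyl in place of iodo on an aromatic carbon in the second. In this assay that change gave an at least 3.1-fold higher number from compound 2 to compound 1 (0.50 log units; beyond the scatter), running into a limit. Compound 3 already sits at the limit of > 20000 nM in this assay, at which 2 of the 3 values shown sit. Compound 4 is therefore expected to stay at that limit, estimated at 40000 nM with a range of 15000 nM to 200000 nM. The expected step is a step that the limit leaves unreadable from compound 3 to compound 4, because of an at least 3.1-fold higher number from compound 2 to compound 1 (0.50 log units; beyond the scatter).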

Compound 4, half-maximal inhibitory concentration: > 20000 nM
Compound 4: no number, only a limit; the forecaster's own chance of this, stated with the estimate: 90%; the middle value lies beyond the limit too.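

Compound 3 and compound 4 each give only a limit, so no step between them can be read: the limit of > 20000 nM in this assay, at which 3 of the 4 values shown sit.

The compounds shown leave open whether phenyl in place of iodo changes activity at all on the core of compound 3.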